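The source may report more compounds than this note shows. Statements on the series, on what has been measured and on what is new or still open speak of the compounds shown alone.

In a functional assay on CCRF-CEM cells (Homo sapiens), read by MTT assay, with a stated time of 72 h (on this read-out lower numbers stand for stronger inhibition and higher numbers for weaker inhibition), compound 1 `COc1ncnc2c1c(-c1cc3ccccc3o1)cn2[C@@H]1O[C@H](CO)[C@@H](O)[C@H]1O` gives 5370 nM. Compound 2 `COc1nc(N)nc2c1c(-c1ccoc1)cn2[C@@H]1O[C@H](CO)[C@@H](O)[C@H]1O` reads > 20000 nM, and this is a limit of the assay rather than a number. Going by these compounds, compound 2 therefore has no exact place on the scale, and its true value remains unknown. These two compounds differ in more than one place, so their readings do not isolate the effect of any single change.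

Compound 3 `COc1nc(N)nc2c1c(-c1ccccc1)cn2[C@@H]1O[C@H](CO)[C@@H](O)[C@H]1O` keeps the core of compound 2 and changes one group: phenyl in place of furan-3-yl on an aromatic carbon. For the measured compounds named here, no measured pair here shows what this swap does in this assay, so no large step in either direction is expected. The starting point is compound 2 at > 20000 nM, again a limit, and compound 3 is expected to stay weak in the same region, quite possibly returning only a limit too. The estimated change is a number no higher from compound 2 to compound 3 (the limit leaves the size open). For compound 3 the expected value is 20000 nM, with an estimated range from 8000 nM to 40000 nM.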

Compound 3, half-maximal inhibitory concentration: > 20000 nM
Compound 3 ended at the assay's limit (the forecaster's own chance of this, stated with the estimate: 70%); the middle value sits exactly at the limit.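

Compound 2 and compound 3 both return a limit of the assay rather than a number, so no step between them can be read in this assay, because both sit at the same limit: the limit of > 20000 nM in this assay, at which 2 of the 3 values shown sit.

The compounds shown leave open whether phenyl and furan-3-yl on this aromatic carbon differ at all in this assay.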